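This account rests on a few compounds, and the source may have more. Where it says the series, first, only, none or still open, it means among the compounds named here.

Working notes on the dihydrobenzofuran series, in a physicochemical assay for lipophilicity, using the shake flask method, in phosphate buffer, measured as octanol-water partition, with a stated time of 30 min, at pH 7.4; a lower number here means a more polar compound, a higher number a more lipophilic compound.

Three compounds have numbers. Compound 1 `Cc1ncccc1-c1cnc(NCc2c(F)ccc3c2CCO3)c2nn(CC#N)c(=O)n12` gives 2.2. Compound 2 `CN(c1ncco1)c1cnc(NCc2c(F)ccc3c2CCO3)n2cnnc12` gives 2.1. Compound 3 `Cc1nc(CN(C)C)ccc1-c1cnc(NCc2c(F)ccc3c2CCO3)c2cn[nH]c(=O)c12` gives 2. Compound 2 sits with compound 1 one way and compound 3 the other, each gap within the scatter, so the three values form one band and no order among them can be read.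

Compound 4 `Fc1ccc2c(c1CNc1ncc(Nc3ccccc3)c3nncn13)CCO2` is not yet measured in this assay. It differs from compound 2 in one place: anilino in place of methyl(1,3-oxazol-2-yl)amino on an aromatic carbon. The group that leaves carries one five-membered aromatic ring with 2 hetero atoms and 3 hydrogen-bond acceptors; the group that enters carries one six-membered aromatic ring of carbon only, with 1 hydrogen-bond donor and 1 hydrogen-bond acceptor. Among the measured compounds shown here, no measured pair in the set shows this exchange, so the size of the step rests on the change alone. An upward step of a number 0.70 log units higher from compound 2 to compound 4 (beyond the scatter) is expected, beyond the scatter. For compound 4 the estimate in this assay is 2.8, with a range from 2.3 to 3.3.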

Compound 4, distribution coefficient: 3.3
Beside the measured number, compound 4's estimate is 0.50 log units below it, within the range that was stated.
By their numbers in this assay, from the lowest: compounds 3, 2 and 1 (each within the scatter of the next); then compound 4.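

In this assay, among the compounds shown here, anilino in place of methyl(1,3-oxazol-2-yl)amino gives the first step in the set between compounds that differ in one place, a number 1.20 log units higher from compound 2 to compound 4 (beyond the scatter), so this position on the six-membered aromatic ring with 2 nitrogen can carry a large change in the number. Both groups hold 7 heavy atoms, so the step comes with an exchange of ring type and of hydrogen-bond donor and acceptor counts, with no change in heavy-atom count. Nothing available bears on the cause of the step.

Open, on these data alone, is which part of the exchange goes with the step: a methyl(phenyl)amino group or a pyridin-2-ylamino group at this position would separate the ring from the hydrogen on the linking nitrogen. Also open, as far as these compounds go, is whether the same exchange gives a step of similar size on the core of compound 1.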